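Notes on a chloro step from compound 1

A few compounds are considered here, and "the series" means these few. Any claim that something is new, unique, unknown or untested is made for them only; others in the source may bear on it.

Measured so far in a functional assay on B16-F10 cells (Mus musculus) for inhibition, read by MTT assay, with a stated time of 72 h; a lower number here means a stronger inhibitor, a higher number a weaker inhibitor
- compound 1 `CC1(C)CC(NC(=O)Nc2ccccc2)c2cc(Cl)ccc2O1`: "not determined" (no result reported)
- compound 2 `CC1(C)CC(NC(=S)Nc2ccc([N+](=O)[O-])cc2)c2cc(Cl)ccc2O1`: 3000 nM

Compound 1 has no usable position on the numbers: in this assay compound 1 stands at "not determined" (no result reported), so there is no single value from which to start. Within the data shown here, the only number is that of compound 2 at 3000 nM, and two entries show no trend.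

The next compound to be tested is compound 3 `CC1(C)CC(NC(=O)Nc2cccc(Cl)c2)c2cc(Cl)ccc2O1`. The change is chloro in place of hydrogen on an aromatic carbon, meta to a large group, which turns phenyl into 3-chlorophenyl.

Among the measured compounds shown here, no step between measured compounds exists to size this change. A modest step towards stronger inhibition is expected, but this expectation is weakly supported, and a step no larger than the scatter would not surprise. With only compound 2 at 3000 nM as a guide, the range is kept wide. For compound 3 the estimated value is 6000 nM, with an expected range from 1500 nM to 25000 nM.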

Compound 3, half-maximal inhibitory concentration: 25000 nM
Beside the measured number, compound 3's estimate is 4.2-fold (0.62 log units) below it; the range from low to high includes it.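

In this assay compound 1 stands at "not determined" (no result reported) and compound 3 at 25000 nM with no number on the compound 1 side, so no step can be read between the two. The compounds shown leave open the size and direction of the change from phenyl to 3-chlorophenyl in this series. No measured evidence bears on this result.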